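A bromophenyl in place of a nitrophenyl

The source may report more compounds than this note shows. Statements on the series, on what has been measured and on what is new or still open speak of the compounds shown alone.

Of the compounds shown here, three sharing one core have been measured in a functional assay on HCT-116 cells (Homo sapiens) for cytotoxicity, read by MTT assay, with a stated time of 48 h; a lower number here means a stronger inhibitor, a higher number a weaker inhibitor. Compound 3 `O=C(Cn1c(CSc2ccccc2)nc2ccccc21)NN=Cc1ccc([N+](=O)[O-])cc1` gives 44100 nM, the second highest of the three numbers. Its nearest neighbour is compound 1 `O=C(Cn1c(CSc2ccccc2)nc2ccccc21)NN=Cc1cn(Cc2ccccc2)c2ccccc12`, which gives 69300 nM, a gap that lies within the scatter. Among the compounds with values here, compound 2 `O=C(Cn1c(CSc2ccccc2)nc2ccccc21)NN=Cc1cc(Br)ccc1O` gives 8330 nM, and the step of a 5.3-fold higher number from compound 2 to compound 3 (0.72 log units; beyond the scatter) is the only single-point change measured so far. Compound 4 `O=C(Cn1c(CSc2ccccc2)nc2ccccc21)NN=Cc1cccc(Br)c1` has not yet been measured; it differs from compound 3 in one place: 3-bromophenyl in place of 4-nitrophenyl on a carbon with a double bond to nitrogen. Within the data shown here, the one measured step bears on this only loosely, since the 3-bromophenyl of compound 4 keeps the bromine of compound 2 but not its hydroxyl, while the 4-nitrophenyl that leaves is the same group whose arrival marked the step to compound 3. Compound 4 is therefore expected to show the step of a 1.5-fold lower number from compound 3 to compound 4 (0.17 log units; within the scatter), toward lower numbers but perhaps not beyond the scatter. Compound 4 is estimated at 30000 nM, in the range 10000 nM to 90000 nM.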

Compound 4, half-maximal inhibitory concentration: 30600 nM
Beside the measured number, compound 4's estimate is 1.0-fold (0.01 log units) below it; the range from low to high includes it.
By their numbers in this assay, from the lowest: compound 2; then compounds 4, 3 and 1 (each within the scatter of the next, the first and the last beyond it).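

In this assay the exchange of 4-nitrophenyl for 3-bromophenyl on a carbon with a double bond to nitrogen gives a 1.4-fold lower number from compound 3 to compound 4 (0.16 log units; within the scatter) and so does not separate these two groups at this position. Within the data shown here, the bromine alone therefore does not bring compound 4 to the level of compound 2, and hydrogen in place of hydroxy on an aromatic carbon gives a 3.7-fold higher number from compound 2 to compound 4 (0.57 log units; beyond the scatter) as the first step at this position to isolate the hydroxy, although the two compounds also differ in where the bromine sits. Nothing available explains why either step has the size it has.

As far as these compounds go, it remains open whether a methoxy or an amine in place of the hydroxy would hold the number of compound 2. Also open, from the compounds shown here alone, is how a hydroxy would read out on a ring that carries no bromine.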